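The source may report more compounds than this note shows. Statements on the series, on what has been measured and on what is new or still open speak of the compounds shown alone.

Three compounds share one core and end in a hydroxamic acid. In an assay on Sf9 cells for inhibition of protein deacetylase HDAC6 (Homo sapiens), read by fluorescence, with a stated time of 40 min (a higher number here means a weaker inhibitor, a lower number a stronger inhibitor), compound 1 `Cc1cccc(-c2nc(CNc3ccc(C(=O)NO)cc3)n(-c3ccccc3)n2)c1` gives 281 nM, compound 3 `Cc1ccc(-c2nc(CNc3ccc(C(=O)NO)cc3)n(-c3ccccc3)n2)cc1` gives 224 nM, and compound 2 `O=C(NO)c1ccc(NCc2nc(-c3ccccc3)nn2-c2ccccc2Cl)cc1` gives 669 nM, the highest of the three numbers and beyond the scatter from both others. Compound 4 `Cc1cccc(-n2nc(-c3ccccc3)nc2CNc2ccc(C(=O)NO)cc2)c1` is not yet measured. It differs from compound 2 in one place: 3-methylphenyl in place of 2-chlorophenyl on an aromatic nitrogen. Among the compounds with values here, the only measured step, a 1.3-fold lower number from compound 1 to compound 3 (0.10 log units; within the scatter), swaps 4-methylphenyl for 3-methylphenyl on an aromatic carbon, not on the aromatic nitrogen, so it gives no direct guide. Compounds 1 and 3 both carry plain phenyl on that nitrogen and both sit lower than compound 2, which suggests that a change there can matter. For compound 4 the expected result in this assay is 350 nM, within 150 nM to 900 nM. That amounts to an expected step of a 1.9-fold lower number from compound 2 to compound 4 (0.28 log units; within the scatter).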

Compound 4, half-maximal inhibitory concentration: 388 nM
The estimate for compound 4 lay 1.1-fold (0.04 log units) below the measured number, and the stated range covers the measured number.
By their numbers in this assay, from the lowest: compounds 3, 1, 4 and 2 (each within the scatter of the next, the first and the last beyond it).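

Within the data shown here, this is the first step read directly on the aromatic nitrogen: 3-methylphenyl in place of 2-chlorophenyl gives a 1.7-fold lower number from compound 2 to compound 4 (0.24 log units; within the scatter) and so separates the two compounds no more than repeated measurements would. The position accepts either substituted phenyl without a clear difference, although this single swap changes both the substituent and where it sits on the phenyl, so those two changes cannot be told apart. Still open, as far as these compounds go, is whether a phenyl carrying an amine or a carboxylic acid, or a longer chain on that nitrogen, would give a clearly different number. No evidence is available to explain this result.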